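Phenyl to Methoxy and Cytotoxicity Toward Skin Cells

The source may hold more compounds than are shown below. What is called first, only, known or untested is meant among the compounds shown, and "the series" means these compounds.

Three compounds sharing a core were tested in an ADME assay on BJ cells (Homo sapiens) for cytotoxicity, read by luminescence, with a stated time of 72 h; on this read-out higher numbers stand for an effect only at larger amounts of compound and lower numbers for an effect already at smaller amounts. Compound 1 `CCOC(=O)c1c(-c2cccc(-c3ccccc3)c2)[nH]c2cc(Cl)c(OC)cc2c1=O` gives > 21500 nM, which is a limit rather than a number. Compound 2 `CCOC(=O)c1c(-c2cccc(OC)c2)[nH]c2cc(Cl)c(OC)cc2c1=O` gives > 21500 nM, again only a limit. Compound 3 `CCOC(=O)c1c(-c2cccc(-c3ccccc3)c2)[nH]c2cc(OC)c(F)cc2c1=O` likewise gives > 21500 nM, a limit. Going from compound 1 to compound 2 means (methoxy in place of phenyl on an aromatic carbon), and in this assay the step is a step that the two limits leave unreadable from compound 1 to compound 2. How the core of compound 1 differs from the core of compound 3 is not broken down here.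

Compound 4 `CCOC(=O)c1c(-c2cccc(OC)c2)[nH]c2cc(OC)c(F)cc2c1=O` has not yet been measured in this assay. Among the compounds with values here, it differs from compound 3 by methoxy in place of phenyl on an aromatic carbon, the same change as the one from compound 1 to compound 2. Within the data shown here, the step from compound 3 to compound 4 is expected to be a step that the limit leaves unreadable from compound 3 to compound 4, because the limit of > 21500 nM in this assay, at which 3 of the 3 values shown sit, shows that every compound measured so far sits at the same limit. Compound 4 is therefore estimated to give 30000 nM in this assay, most likely reported once more as a limit rather than as a number.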

Compound 4, half-maximal effective concentration: > 21500 nM
Compound 4: a limit, no number; the forecaster's own chance of this, stated with the estimate: 85%; the middle value does not contradict the limit.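

No new step can be read from compound 3 to compound 4, since both give only a limit in this assay, as do compound 1 and compound 2: the limit of > 21500 nM in this assay, at which 4 of the 4 values shown sit.

The compounds shown leave open whether methoxy in place of phenyl on an aromatic carbon changes cytotoxicity at all, and at what amount of compound any of the four would show an effect.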